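A few compounds are considered here, and "the series" means these few. Any claim that something is new, unique, unknown or untested is made for them only; others in the source may bear on it.

Measured in a functional assay on KB cells (Homo sapiens) for inhibition, read by sulforhodamine B assay, with a stated time of 72 h; on this read-out lower numbers stand for stronger inhibition of growth and higher numbers for weaker inhibition of growth:
Compound 1 `CNC(=O)/C=C/c1ccncc1-c1ccc2ccccc2c1`: > 10000 nM, a limit.
Compound 2 `CCOC(=O)/C=C/c1ccncc1-c1ccc2cc[nH]c2c1`: 7860 nM.
Compound 3 `NC(=O)/C=C/c1ccncc1-c1ccc2ccccc2c1`: > 10000 nM, a limit.

Among the measured compounds shown here, compound 2 holds the only actual number in this set. Compound 1 and compound 3 sit at the limit of > 10000 nM in this assay, at which 2 of the 3 values shown sit. Compound 4 `O=C(O)/C=C/c1ccncc1-c1ccc2cc[nH]c2c1` differs from compound 2 by hydrogen in place of ethyl on an oxygen next to a carbonyl group, that is, ethoxycarbonyl to carboxy. For the measured compounds named here, the one measured step, a step that the two limits leave unreadable from compound 1 to compound 3, concerns an amide-type nitrogen and gives no size, so no measured step bears on this change. The reference point is therefore compound 2 at 7860 nM alone. The estimated 1.3-fold higher number from compound 2 to compound 4 (0.10 log units; within the scatter) is expected to stay within the usual scatter, leaning toward weaker inhibition of growth, and a limit is quite possible. For compound 4 the estimate is 10000 nM, with an expected range of 5000 nM to 20000 nM.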

Compound 4, concentration for 50% growth inhibition: > 10000 nM
Compound 4: no number, only a limit; the forecaster's own chance of this, stated with the estimate: 60%; the middle value lies on the limit itself.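

In this assay, the change from ethoxycarbonyl to carboxy, on an oxygen next to a carbonyl group, now has a floor on its size: an at least 1.2-fold higher number from compound 2 to compound 4 (0.10 log units; that floor lies within the scatter). Going by these compounds, compound 4 gives a limit and not a number, so the true size of the step stays unknown and may or may not exceed the scatter. Compound 2 remains the only compound with an actual number: the limit of > 10000 nM in this assay, at which 3 of the 4 values shown sit.

On these data alone, it remains open whether any other group on this oxygen would give a lower number than compound 2. A methyl group, a longer chain such as butyl, or an ethyl chain carrying an amine are not among the compounds shown.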